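Bromine on the Phenyl Ring of Compound 1

The source may hold more compounds than are shown below. What is called first, only, known or untested is meant among the compounds shown, and "the series" means these compounds.

Going by the values given here, compound 1 `Cc1cc(O)c(C(=O)/C=C/c2ccc(Cl)cc2)c(-c2ccccc2)c1C(=O)/C=C/c1ccc(Cl)cc1` is the only compound here with a number: in a functional assay on MDA-MB-231 cells (Homo sapiens) for cytotoxicity, read by MTT assay, with a stated time of 24 h (on this read-out lower numbers stand for stronger inhibition and higher numbers for weaker inhibition), compound 1 gives 7900 nM. Compound 2 `Cc1cc(O)c(C(=O)/C=C/c2ccc3ccccc3c2)c(-c2ccc(Cl)cc2)c1C(=O)/C=C/c1ccc2ccccc2c1` is reported in this assay as "not active" (no number reported), without a number, so the two values cannot be compared. Compound 3 `Cc1cc(O)c(C(=O)/C=C/c2ccc(Cl)cc2)c(-c2ccc(Br)cc2)c1C(=O)/C=C/c1ccc(Cl)cc1` differs from compound 1 in one place: bromo in place of hydrogen on an aromatic carbon. Among the compounds with values here, no measured pair shows this change, so its effect is unknown; the expected step of a 1.3-fold higher number from compound 1 to compound 3 (0.10 log units; within the scatter) is small, not beyond the scatter, with at most a slight lean toward weaker inhibition. Compound 3 is therefore estimated at 10000 nM, within 3000 nM to 35000 nM.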

Compound 3, half-maximal inhibitory concentration: 15000 nM
Beside the measured number, compound 3's estimate is 1.5-fold (0.18 log units) below it; the range from low to high includes it.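

In this assay, the swap from phenyl to 4-bromophenyl gives a 1.9-fold higher number from compound 1 to compound 3 (0.28 log units; within the scatter) and so gives the first measured pair differing in one place. On this evidence, bromo on this aromatic carbon leaves cytotoxicity indistinguishable from that with hydrogen, so this position accepts the bromine atom without a clear loss. No supporting measurement bears on what lies behind this result.

As far as these compounds go, whether an amine or a carboxylic acid on the same carbon would move the number beyond the usual scatter stays open. So does whether bromo would act the same way with other groups elsewhere on the shared core.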